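Methyl for bromo on the ester aryl ring of a menthyl benzoate

The source may report more compounds than this note shows. Statements on the series, on what has been measured and on what is new or still open speak of the compounds shown alone.

The study compares three measured esters that share one menthol-derived alcohol portion. Compound 1 `CC(C)[C@@H]1CC[C@@H](C)C[C@H]1OC(=O)c1cccc(Br)c1` carries a bromo group, and compound 2 `CC(C)[C@@H]1CC[C@@H](C)C[C@H]1OC(=O)c1ccccc1Br` the same atoms joined differently; the difference between the two cores is not broken down here. Compound 3 `Cc1ccccc1C(=O)O[C@@H]1C[C@H](C)CC[C@H]1C(C)C` replaces the bromo of compound 2 with a methyl, a change counted as methyl in place of bromo on an aromatic carbon. In a physicochemical assay for lipophilicity, measured as octanol-water partition (a lower number here means a more polar compound, a higher number a more lipophilic compound), compound 1 gives 5.61, compound 2 gives 5.61 and compound 3 gives 5.29. Among the measured compounds shown here, compounds 1 and 2 are level within the scatter, and the one measured step, a number 0.32 log units lower from compound 2 to compound 3 (beyond the scatter), is modest but beyond the scatter.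

Compound 4 `Cc1cccc(C(=O)O[C@@H]2C[C@H](C)CC[C@H]2C(C)C)c1` has not yet been measured. It differs from compound 1 by methyl in place of bromo on an aromatic carbon; the methyl here sits meta to a large group rather than ortho, so this is the same kind of change as that from compound 2 to compound 3, not the same change. For the measured compounds named here, the step from compound 1 to compound 4 is expected to be a number 0.32 log units lower from compound 1 to compound 4 (beyond the scatter), resting on the measured step of a number 0.32 log units lower from compound 2 to compound 3 (beyond the scatter) as its only precedent. Compound 4 is therefore estimated at 5.29, between 5 and 5.6.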

Compound 4, partition coefficient: 5.29
For compound 4 middle estimate and measured number coincide at the digits printed; the measured number falls inside the stated range.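

In this assay, methyl in place of bromo on the core of compound 1 gives a number 0.32 log units lower from compound 1 to compound 4 (beyond the scatter), and this matches at the digits printed the step on the other core, a number 0.32 log units lower from compound 2 to compound 3 (beyond the scatter), so the change carried over between these two cores with its size unchanged. This rests on just two pairs, so it shows agreement between these two cores and not a rule that would hold on any further core in the series. Nothing shown explains why the two steps agree.

The compounds shown leave open whether the same size of step would appear with other groups on the aromatic ring, such as an amine, a carboxylic acid or a longer chain, in place of bromo or methyl. They also leave open whether methyl in place of bromo would give a similar step on an ester with an alcohol portion other than the menthol-derived one.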